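A few compounds are considered here, and "the series" means these few. Any claim that something is new, unique, unknown or untested is made for them only; others in the source may bear on it.

Of the compounds shown here, three built on the same core have been measured in an assay on Sf9 cells for inhibition of mitogen-activated protein kinase kinase kinase 20 (Homo sapiens), read by ADP-Glo, with a stated time of 30 min; a higher number here means a weaker inhibitor, a lower number a stronger inhibitor. Compound 1 `COc1n[nH]c2ncc(-c3nnc(-c4c(F)ccc(NS(=O)(=O)c5cccc(Cl)c5)c4F)o3)cc12` gives 63.3 nM in this assay. Compound 2 `COc1n[nH]c2ncc(-c3cn(-c4cccc(NS(=O)(=O)c5cccc(Cl)c5)c4)nn3)cc12` gives 24.7 nM in this assay. Compound 3 `COc1n[nH]c2ncc(-c3cn(-c4c(F)ccc(NC(=O)c5cccc(Cl)c5)c4F)nn3)cc12` gives 54.3 nM in this assay, the second highest of the three numbers; its gap to compound 1 lies within the scatter, while compound 2 sits lower by a gap beyond the scatter.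

Compound 4 `COc1n[nH]c2ncc(-c3cn(-c4c(F)ccc(NS(=O)(=O)c5cccc(C#N)c5)c4F)nn3)cc12` has not yet been measured. It differs from compound 3 in one place: (3-cyanophenyl)sulfonyl in place of (3-chlorophenyl)carbonyl on a nitrogen on an aromatic ring. Among the measured compounds shown here, no measured pair shows this change by itself. For the measured compounds named here, compound 2 and compound 3 carry a sulfonyl link and a carbonyl link, but they also differ in their fluorines, so their two values show only that the sulfonyl compound sits lower. A modest downward step is therefore expected, a 1.6-fold lower number from compound 3 to compound 4 (0.19 log units; within the scatter), although a flat outcome within the scatter would not surprise. Compound 4 is estimated to give 35 nM in this assay, with a range from 12 nM to 100 nM.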

Compound 4, half-maximal inhibitory concentration: 3.3 nM
Compound 4: the middle estimate sits 11-fold (1.03 log units) above what was measured, and the stated range ends above it.
By their numbers in this assay, from the lowest: compound 4; then compound 2; then compounds 3 and 1 (each within the scatter of the next).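

In this assay, the change on the nitrogen on an aromatic ring gives a 16-fold lower number from compound 3 to compound 4 (1.22 log units; beyond the scatter), a large step and one beyond the scatter, so this position can strongly affect the reading. The earlier compounds shown here showed no step at this position, and none of their differences could be read as one change. Here, (3-cyanophenyl)sulfonyl in place of (3-chlorophenyl)carbonyl is tied directly to a much lower number, with the rest of the structure held the same. Nothing shown here accounts for the size of this step.

The replacement alters both the link and the group on the outer ring, so the compounds shown cannot divide the step between the sulfonyl and the nitrile. As far as these compounds go, it also remains open how an amine or a carboxylic acid would read in place of that nitrile.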